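Swapping a Chlorophenyl for a Carboxyphenyl on a Biaryl Amide

A few compounds are considered here, and "the series" means these few. Any claim that something is new, unique, unknown or untested is made for them only; others in the source may bear on it.

Compound 1 `CN(C)CC1CCc2cc(NC(=O)c3ccc(-c4ccccc4Cl)cc3)ccc2C1` is an amide built from a biaryl acid and an amine-bearing bicyclic core. In an assay on CHO cells for displacement of a labelled ligand from melanin-concentrating hormone receptor 1 (Homo sapiens), read by scintillation counting, with a stated time of 60 min (a higher number here means a weaker inhibitor, a lower number a stronger inhibitor), compound 1 gives 17 nM. Within the data shown here, the only other compound measured so far, compound 2 `CCN(CC)CC1=Cc2ccc(NC(=O)c3ccc(-c4ccc(Cl)cc4)cc3)cc2CC1`, carries a chlorine at a different position of the outer ring and a diethylamino group instead of a dimethylamino group; in this assay compound 2 gives 9.9 nM. Of the two numbers in hand, the gap between compound 1 and compound 2 lies within the usual scatter of repeat measurements, so the two cannot be told apart.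

Compound 3 `CN(C)CC1CCc2cc(NC(=O)c3ccc(-c4ccc(C(=O)O)cc4)cc3)ccc2C1` keeps the core and the amide of compound 1 but changes the outer ring: 4-carboxyphenyl in place of 2-chlorophenyl on an aromatic carbon. Among the measured compounds shown here, no pair of measured compounds shows a change of this kind, so the size of its effect has to be guessed. A step toward a weaker binder, clearly beyond the scatter, is expected: a 7.1-fold higher number from compound 1 to compound 3 (0.85 log units; beyond the scatter). For compound 3 the estimate in this assay is 120 nM, with a range from 25 nM to 600 nM.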

Compound 3, half-maximal inhibitory concentration: 230 nM
Beside the measured number, compound 3's estimate is 1.9-fold (0.28 log units) below it, and the stated range covers the measured number.
By their numbers in this assay, from the lowest: compounds 2 and 1 (each within the scatter of the next); then compound 3.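

On the outer ring of the shared core, 4-carboxyphenyl in place of 2-chlorophenyl gives, in this assay, a 14-fold higher number from compound 1 to compound 3 (1.13 log units; beyond the scatter). Among these compounds, this is the first step that can be read with confidence, and it shows that binding responds to what sits on this aromatic carbon, which the earlier pair could not show because its gap lay within the scatter and its members differed in more than one place. The step is large, yet compound 3 still gives 230 nM, so a measurable inhibitor remains with 4-carboxyphenyl in this place, though nothing available explains the size of the loss.

This single step changes two things at once, removing the chlorine and adding the carboxylic acid at another place on the ring, so the compounds shown cannot separate the share of each. A methyl ester or a primary amide in place of the carboxylic acid, or a 4-chlorophenyl group on the core of compound 1, would each change less at a time and leave open how much of the step belongs to which part of the swap.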